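The source may report more compounds than this note shows. Statements on the series, on what has been measured and on what is new or still open speak of the compounds shown alone.

Compound 1 `COc1ccc(-c2nc3cc(/C(C)=N/NC(N)=S)ccc3[nH]2)cc1`: 13000 nM
Compound 2 `C/C(=N\NC(N)=S)c1ccc2c(c1)nc(-c1ccccc1)n2C1CCCCC1`: 24000 nM
Compound 3 `COc1ccc(-c2nc3cc(/C(C)=N/NC(N)=S)ccc3n2C2CCCCC2)cc1`: not yet measured

In an ADME assay on MDBK cells (Bos taurus) for cytotoxicity, read by MTT assay, with a stated time of 96 h (on this read-out higher numbers stand for lower toxicity in this test and lower numbers for higher toxicity in this test), compound 2 gives 24000 nM, the higher of the two numbers, though compound 1 at 13000 nM lies within the scatter of it. Compound 3 differs from compound 2 by methoxy in place of hydrogen on an aromatic carbon, para to a large group, phenyl to 4-methoxyphenyl: methoxy in place of hydrogen on an aromatic carbon. Among the compounds with values here, no measured pair isolates this change. Compound 1 also carries 4-methoxyphenyl and gives 13000 nM, so only a small downward shift is expected, none beyond the scatter: the expected move is a 1.3-fold lower number from compound 2 to compound 3 (0.12 log units; within the scatter). For compound 3 the estimated value is 18000 nM, with an expected range of 7000 nM to 45000 nM.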

Compound 3, half-maximal cytotoxic concentration: 32000 nM
Estimate against measurement, compound 3: 1.8-fold (0.25 log units) below; measured number inside the range.
By their numbers in this assay, from the lowest: compounds 1, 2 and 3 (each within the scatter of the next, the first and the last beyond it).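

In this assay, methoxy in place of hydrogen on an aromatic carbon, para to a large group, now has a measured pair: a 1.3-fold higher number from compound 2 to compound 3 (0.12 log units; within the scatter), so with cyclohexyl present this change stays within the scatter. Cyclohexyl in place of hydrogen on an aromatic nitrogen gives a 2.5-fold higher number from compound 1 to compound 3 (0.39 log units; beyond the scatter), a modest step and the only single-place change here beyond the scatter. No measurement available here accounts for either step.

Open, on these data alone, are how a hydroxyl or chlorine would read in place of methoxy, and how methyl would read in place of cyclohexyl.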